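Methyl in Place of Methoxy: What to Expect for Compound 4

The source may report more compounds than this note shows. Statements on the series, on what has been measured and on what is new or still open speak of the compounds shown alone.

Compound 1 `COc1ccccc1C(=O)Nc1cccc(-c2oc3cc(-c4ccc(F)cc4)ccc3c(=O)c2O)c1`: 11700 nM
Compound 2 `Cc1ccccc1C(=O)Nc1cccc(-c2oc3cc(-c4ccc(F)cc4)ccc3c(=O)c2O)c1`: 17600 nM
Compound 3 `COc1cccc(C(=O)Nc2cccc(-c3oc4cc(-c5ccc(F)cc5)ccc4c(=O)c3O)c2)c1`: 10800 nM

These three compounds were measured in a functional assay on A549 cells (Homo sapiens) for antiproliferative activity, read by CCK-8 assay, with a stated time of 72 h; a lower number here means a stronger inhibitor, a higher number a weaker inhibitor. Compound 4 `Cc1cccc(C(=O)Nc2cccc(-c3oc4cc(-c5ccc(F)cc5)ccc4c(=O)c3O)c2)c1` has not been measured yet. It differs from compound 3 by methyl in place of methoxy on an aromatic carbon. The same change, methyl in place of methoxy on an aromatic carbon, has already been made once, from compound 1 to compound 2 (methyl in place of methoxy on an aromatic carbon), where it gave a 1.5-fold higher number from compound 1 to compound 2 (0.18 log units; within the scatter). The two cores are not identical: compound 3 differs from compound 1 by 3-methoxyphenyl in place of 2-methoxyphenyl on a carbonyl carbon, which gave a 1.1-fold lower number from compound 1 to compound 3 (0.03 log units; within the scatter). The place also differs in its words, ortho to a large group in the first case and meta to a large group in the second, so the two changes are of the same kind rather than the same. Compound 2 and compound 3 are separated by a 1.6-fold lower number from compound 2 to compound 3 (0.21 log units; within the scatter). For compound 4 the expected step in this assay is a 1.4-fold higher number from compound 3 to compound 4 (0.14 log units; within the scatter), because the earlier change gave a 1.5-fold higher number from compound 1 to compound 2 (0.18 log units; within the scatter). The estimate for compound 4 in this assay is 15000 nM, expected to fall between 7000 nM and 35000 nM.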

Compound 4, half-maximal inhibitory concentration: 16500 nM
Compound 4: the middle estimate sits 1.1-fold (0.04 log units) below what was measured; the range from low to high includes it.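

In this assay, methyl in place of methoxy gave a 1.5-fold higher number from compound 3 to compound 4 (0.18 log units; within the scatter), and the change carried over from one core to the other with no readable difference: the same change on two cores in this assay, a 1.5-fold higher number (0.18 log units; within the scatter) from compound 1 to compound 2 and a 1.5-fold higher number (0.18 log units; within the scatter) from compound 3 to compound 4, 1.0-fold (0.01 log units) apart, within the scatter of two such steps. For the compounds shown here, this does not show that a real effect of the change travels between cores: both steps lie within the scatter, so the agreement could be that of two steps too small to read, and it rests on only two cores. The other new steps, a 1.1-fold lower number from compound 2 to compound 4 (0.03 log units; within the scatter) with 3-methylphenyl in place of 2-methylphenyl and a 1.4-fold higher number from compound 1 to compound 4 (0.15 log units; within the scatter) with 3-methylphenyl in place of 2-methoxyphenyl, are also within the scatter, so none of these changes can be told apart from repeat measurement.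

The compounds shown carry only methyl or methoxy on this aromatic ring, so it stays open whether an amine, a carboxylic acid or a longer chain there would give a step beyond the scatter. From the compounds shown here alone, it also stays open whether methyl in place of methoxy behaves the same way on cores that differ more widely from these.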